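This account rests on a few compounds, and the source may have more. Where it says the series, first, only, none or still open, it means among the compounds named here.

Working notes on the series.

The shared core is carried by compound 1 `Cc1cc(S(N)(=O)=O)ccc1NC(=O)COc1ccc2ccccc2c1C(=O)c1cccc(Cl)c1`, compound 2 `Cc1ccc(C(=O)c2c(OCC(=O)Nc3ccc(S(N)(=O)=O)cc3C)ccc3ccccc23)c(C)c1` and compound 3 `Cc1cc(S(N)(=O)=O)ccc1NC(=O)COc1ccc2cc(Br)ccc2c1C(=O)c1cccc(Cl)c1`. In an ADME assay on C8166 cells (Homo sapiens) for cytotoxicity, read by colorimetric assay and MTT assay (on this read-out higher numbers stand for lower toxicity in this test and lower numbers for higher toxicity in this test), compound 1 gives 37400 nM, compound 2 gives 25500 nM and compound 3 gives 6800 nM. Among the three numbers compound 3 has the lowest; its nearest neighbour is compound 2, and the gap to both other compounds is beyond the scatter.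

Compound 4 `Cc1ccc(C(=O)c2c(OCC(=O)Nc3ccc(S(N)(=O)=O)cc3C)ccc3cc(Br)ccc23)cc1C` has not been measured. Relative to compound 3 the change is 3,4-dimethylphenyl in place of 3-chlorophenyl on a carbonyl carbon. The closest measured step is a 1.5-fold lower number from compound 1 to compound 2 (0.17 log units; within the scatter), where a dimethylphenyl likewise replaced the 3-chlorophenyl, though with the methyl groups in a different pattern. The step of a 5.5-fold lower number from compound 1 to compound 3 (0.74 log units; beyond the scatter) concerns the bromo and does not bear on this change directly, but it sets the baseline of compound 3.

On that basis no step beyond the scatter is expected in this assay; the estimate is a 1.2-fold lower number from compound 3 to compound 4 (0.09 log units; within the scatter), with a slight lean toward a lower number, because compound 2 showed a 1.5-fold lower number from compound 1 to compound 2 (0.17 log units; within the scatter). For compound 4 the expected value is 5500 nM, with a range from 2500 nM to 12000 nM.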

Compound 4, half-maximal cytotoxic concentration: 85200 nM
Beside the measured number, compound 4's estimate is 15-fold (1.19 log units) below it; the measured number lies above the stated range.
By their numbers in this assay, from the lowest: compound 3; then compounds 2 and 1 (each within the scatter of the next); then compound 4.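

In this assay, 3,4-dimethylphenyl in place of 3-chlorophenyl on a carbonyl carbon gives a 13-fold higher number from compound 3 to compound 4 (1.10 log units; beyond the scatter) in a compound that carries the bromo, so this position can move the read-out strongly. The step is opposite in direction to a 5.5-fold lower number from compound 1 to compound 3 (0.74 log units; beyond the scatter) and much larger than a 1.5-fold lower number from compound 1 to compound 2 (0.17 log units; within the scatter) with 2,4-dimethylphenyl and no bromo, so the low number that comes with the bromo in compound 3 does not hold once this group is on the carbonyl carbon, and the earlier step at this position gave no warning of that. Nothing available here explains the step.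

The compounds shown leave open whether the step belongs to the 3,4-dimethylphenyl itself, to the arrangement of its two methyl groups, or to the combination with the bromo, since no pair here separates these readings. As far as these compounds go, how this read-out responds to an amine or a carboxylic acid on the phenyl ring at this position also remains open.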